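A few compounds are considered here, and "the series" means these few. Any claim that something is new, unique, unknown or untested is made for them only; others in the source may bear on it.

In an ADME assay on Vero cells (Chlorocebus sabaeus) for cytotoxicity, read by MTT assay, with a stated time of 96 h (on this read-out lower numbers stand for higher toxicity in this test and higher numbers for lower toxicity in this test), compound 2 `C/C(=N\NC(N)=S)c1ccc2c(c1)nc(-c1ccc(Cl)cc1)n2C1CCCCC1` gives > 100000 nM, which is a limit of the assay and not a number. Compound 3 `COc1ccc(-c2nc3cc(/C(C)=N/NC(N)=S)ccc3n2C2CCCCC2)c(OC)c1` has 2,4-dimethoxyphenyl in place of 4-chlorophenyl on an aromatic carbon. Going by the values given here, compound 1 `COc1ccc(-c2nc3cc(/C(C)=N/NC(N)=O)ccc3n2C2CCCCC2)c(OC)c1`, which also carries 2,4-dimethoxyphenyl, gives 20000 nM in this assay, and this single value is the only guide to the direction. The expected change is a drop beyond the usual scatter, toward higher toxicity in this test, estimated as an at least 2.8-fold lower number from compound 2 to compound 3 (0.45 log units; beyond the scatter). For compound 3 the estimated value is 35000 nM, with an expected range of 10000 nM to 100000 nM.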

Compound 3, half-maximal cytotoxic concentration: 20000 nM
Estimate against measurement, compound 3: 1.8-fold (0.24 log units) above, and the stated range covers the measured number.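

In this assay, 2,4-dimethoxyphenyl in place of 4-chlorophenyl on the aromatic carbon between two ring nitrogen atoms gives an at least 5.0-fold lower number from compound 2 to compound 3 (0.69 log units; beyond the scatter). Compound 2 is read only as a limit of the assay and not a number: the limit of > 100000 nM in this assay, at which 1 of the 3 values shown sits. With 2,4-dimethoxyphenyl in place, the sulfur-bearing group in place of the oxygen-bearing group on the amine nitrogen gives no change at the digits printed from compound 1 to compound 3 (within the scatter).

From the compounds shown here alone, whether one methoxy group alone carries the step remains open. So does how a plain phenyl or a pyridine ring at this carbon would read in this assay.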